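The source may hold more compounds than are shown below. What is called first, only, known or untested is meant among the compounds shown, and "the series" means these compounds.

Measured compounds:
- compound 1 `FC(F)(F)c1ccc(N2CCN(c3ncnc4[nH]cnc34)CC2)cc1`: 3200 nM
- compound 2 `Cc1ccc(S(=O)(=O)n2cnc3c(N4CCN(c5ccc(C(F)(F)F)cc5)CC4)ncnc32)cc1`: 1400 nM
- compound 3 `Cc1ccc(S(=O)(=O)n2cnc3c(NCCC4C=CCCC4)ncnc32)cc1`: 9400 nM

In a functional assay on Huh-7 cells (Homo sapiens) for cytotoxicity, read by sulforhodamine B assay, with a stated time of 72 h (a lower number here means a stronger inhibitor, a higher number a weaker inhibitor), compound 2 gives the lowest of the three numbers, with compound 1 nearest above it and compound 3 furthest. Compound 4 `FC(F)(F)c1ccc(N2CCN(c3ncnc4c3ncn4C3CCCC3)CC2)cc1` differs from compound 2 in one place: cyclopentyl in place of (4-methylphenyl)sulfonyl on an aromatic nitrogen. Among the compounds with values here, only one measured step touches this position, a 2.3-fold lower number from compound 1 to compound 2 (0.36 log units; beyond the scatter), a modest gain from adding (4-methylphenyl)sulfonyl to hydrogen. Within the data shown here, no measured pair shows what cyclopentyl does at that nitrogen, so the direction is open; a step of about the same modest size, either way, seems the fairest expectation. Compound 4 is therefore estimated at 2500 nM, within 900 nM to 7000 nM. That estimate corresponds to an expected 1.8-fold higher number from compound 2 to compound 4 (0.25 log units; within the scatter).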

Compound 4, half-maximal inhibitory concentration: 200 nM
Compound 4: the middle estimate sits 13-fold (1.10 log units) above what was measured; measured number outside the range, below it.
By their numbers in this assay, from the lowest: compound 4; then compound 2; then compound 1; then compound 3.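

In this assay, the group on this aromatic nitrogen matters more than the earlier step suggested: cyclopentyl in place of (4-methylphenyl)sulfonyl gives a 7.0-fold lower number from compound 2 to compound 4 (0.85 log units; beyond the scatter), and cyclopentyl in place of hydrogen gives a 16-fold lower number from compound 1 to compound 4 (1.20 log units; beyond the scatter). So the smaller non-aromatic carbon ring outperforms both the hydrogen and the larger sulfonyl group here. Nothing available explains this gain. On these data alone, whether a methyl group, a cyclohexyl ring or a chain ending in an amine would do better at this nitrogen remains open. So does whether cyclopentyl would bring a similar gain with the side chain of compound 3.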